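The compounds below may be only part of what the source reports. "The series", "measured", "known", "first", "only" and "open" are said of these compounds alone.

Measured in a functional assay on A549 cells (Homo sapiens) for inhibition, read by CCK-8 assay, with a stated time of 72 h, tested at 1 uM; on this read-out higher numbers stand for more inhibition of growth at the one concentration tested and lower numbers for less inhibition of growth:

- Compound 1 `CN(C)C(=O)c1cc2cnc(Nc3ccc(NC(=O)C4(C(=O)Nc5ccc(Cl)cc5)CC4)cc3)nc2n1C1CCCC1`: 24.7%
- Compound 2 `COc1ccc(NC(=O)C2(C(=O)Nc3ccc(Nc4ncc5cc(C(=O)N(C)C)n(C6CCCC6)c5n4)cc3)CC2)cc1`: 74.4%
- Compound 3 `CN(C)C(=O)c1cc2cnc(Nc3ccc(NC(=O)C4(C(=O)Nc5cccc(C#N)c5)CC4)cc3)nc2n1C1CCCC1`: 70.8%

In this assay compound 3 gives 70.8%. That places it level with compound 2, given a number 3.6 percentage points lower from compound 2 to compound 3 (within the scatter), and well clear of compound 1, given a number 46.1 percentage points higher from compound 1 to compound 3 (beyond the scatter).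

The next compound is compound 4 `CN(C)C(=O)c1cc2cnc(Nc3ccc(NC(=O)C4(C(=O)Nc5ccc(C#N)cc5)CC4)cc3)nc2n1C1CCCC1`, which has 4-cyanophenyl in place of 3-cyanophenyl on an amide-type nitrogen. Among the compounds with values here, no measured pair isolates this kind of move, so the evidence is indirect. Changing the aryl group on this nitrogen can matter greatly, as a number 46.1 percentage points higher from compound 1 to compound 3 (beyond the scatter) shows. Among groups named with a 4, the outcome also varied widely, as a number 49.7 percentage points higher from compound 1 to compound 2 (beyond the scatter) shows. Compound 4 could therefore land near either level, though two of the three values are high. A modest fall is expected, estimated as a number 8.8 percentage points lower from compound 3 to compound 4 (within the scatter), and this may not exceed the scatter. For compound 4 the estimated value is 62%, with an expected range from 35% to 82%.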

Compound 4, percent growth inhibition at one concentration: 86.1%
Compound 4: the middle estimate sits 24.1 percentage points below what was measured, outside the stated range (above it).
By their numbers in this assay, from the lowest: compound 1; then compounds 3 and 2 (each within the scatter of the next); then compound 4.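

Swapping 3-cyanophenyl for 4-cyanophenyl on the amide-type nitrogen leaves the atoms the same and only joins them differently, yet it gives a number 15.3 percentage points higher from compound 3 to compound 4 (beyond the scatter) in this assay and shows that where the cyano group sits on this ring matters, not only that it is present. Changing the group on the aromatic carbon instead, cyano in place of methoxy gives a number 11.7 percentage points higher from compound 2 to compound 4 (beyond the scatter) and cyano in place of chloro gives a number 61.4 percentage points higher from compound 1 to compound 4 (beyond the scatter) as the step, which puts compound 4 above all three others. Nothing measured here explains these differences.

On these data alone, it remains open whether the difference between the 3-named and 4-named forms belongs to cyano alone, which a 3-methoxyphenyl partner of compound 2 would test. Also open, as far as these compounds go, is how an amine or a carboxylic acid on the same aromatic carbon would compare with cyano.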